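The source may hold more compounds than are shown below. What is called first, only, known or untested is meant among the compounds shown, and "the series" means these compounds.

Measured so far in a functional assay on RAW264.7 cells (Mus musculus) for inhibition, read by Griess assay, with stated times of 2 h and 18 h; on this read-out higher numbers stand for weaker inhibition and lower numbers for stronger inhibition:

compound 1 (`CC1=C(CCc2ccoc2)[C@@]2(C)CCC(=O)C(C)(C)C2=C(O)C1=O`) gives > 50000 nM as a limit
compound 2 (`C[C@H]1C(=O)[C@@H](O)[C@H]2C(C)(C)C(=O)CC[C@]2(C)[C@@]1(O)CCc1ccoc1`) gives > 50000 nM as a limit
compound 3 (`CC1=C(CCC2=CCOC2=O)[C@@]2(C)CC[C@@H](O)C(C)(C)C2=C(O)C1=O`) gives > 50000 nM as a limit

Compound 1 stands at the edge of what the test reports, with > 50000 nM as a limit and not a number. The other two compounds share that position, and the record reads the limit of > 50000 nM in this assay, at which 3 of the 3 values shown sit, with no exact figure among them. Among the measured compounds shown here, no pair of measured compounds therefore gives a sized step to learn from.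

Compound 4 (`CO[C@@H]1C=C(CCC2=C(C)C(=O)C(O)=C3C(C)(C)C(=O)CC[C@]23C)C(=O)O1`) keeps the core of compound 1 and changes one group, a group of 8 heavy atoms (5 carbon, 3 oxygen; one five-membered non-aromatic ring with 1 hetero atom) in place of a group of 5 heavy atoms (4 carbon, 1 oxygen; one five-membered aromatic ring with 1 hetero atom), on a saturated chain carbon, two bonds along the chain from a double-bonded ring carbon being the full count. A group with a five-membered non-aromatic ring replaces the furan-3-yl group, on a saturated chain carbon, two bonds along the chain from a double-bonded ring carbon. Compound 3 also carries a five-membered non-aromatic ring on its chain, and compound 3 gives > 50000 nM as a limit all the same. A strong gain in this assay is therefore not expected. The expected move an at least 1.1-fold lower number from compound 1 to compound 4 (0.04 log units; that floor lies within the scatter) is small, and towards stronger inhibition if it shows at all. The estimate for compound 4 is 45000 nM with an expected range from 15000 nM to 100000 nM and a good chance of another limit reading.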

Compound 4, half-maximal inhibitory concentration: > 50000 nM
Compound 4: no number, only a limit (the forecaster's own chance of this, stated with the estimate: 70%); at least 1.1-fold (0.04 log units) between middle value and limit.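

Compound 4 gives only a limit in this assay, as compound 1 does, so replacing the furan-3-yl group produces no step of readable size between compound 1 and compound 4: the limit of > 50000 nM in this assay, at which 4 of the 4 values shown sit.

The compounds shown leave open how strongly any of them inhibits, and which structural change, if any, would give an exact number.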